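The source may hold more compounds than are shown below. What is called first, only, known or untested is meant among the compounds shown, and "the series" means these compounds.

Compound 1 `O=C(Nc1ccccc1)c1c(NO)cc(-c2ccccc2)oc1=O`: in an ADME assay on Huh-7 cells (Homo sapiens) for cytotoxicity, read by a luciferase reporter and WST assay, with a stated time of 3 days (on this read-out higher numbers stand for lower toxicity in this test and lower numbers for higher toxicity in this test), compound 1 gives 11600 nM.
Compound 2 `O=C(Nc1ccc(Cl)cc1)c1c(NO)cc(-c2ccccc2)oc1=O`: in this assay compound 2 gives > 20000 nM, a limit of the assay.
Compound 3 `O=C(Nc1ccc(Br)cc1)c1c(NO)cc(-c2ccccc2)oc1=O`: in this assay compound 3 gives > 20000 nM, a limit of the assay.

Compound 3 thus stands at the limit (the limit of > 20000 nM in this assay, at which 2 of the 3 values shown sit). Its step from compound 2 reads a step that the two limits leave unreadable from compound 2 to compound 3. Compound 4 `O=C(Nc1ccc(O)cc1)c1c(NO)cc(-c2ccccc2)oc1=O` differs from compound 3 by hydroxy in place of bromo on an aromatic carbon. Among the measured compounds shown here, no measured step exchanges bromo for hydroxy. The steps that touch this position are an at least 1.7-fold higher number from compound 1 to compound 2 (0.23 log units; that floor lies within the scatter) and an at least 1.7-fold higher number from compound 1 to compound 3 (0.23 log units; that floor lies within the scatter), each only a floor. Compound 1 sits at 11600 nM. Compound 3 sits at the limit. What hydroxy does at this position is unmeasured, so the expected step of an at least 1.3-fold lower number from compound 3 to compound 4 (0.12 log units; that floor lies within the scatter) is set near zero with a wide range. Compound 4 is estimated at 15000 nM, between 6000 nM and 40000 nM.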

Compound 4, half-maximal cytotoxic concentration: > 20000 nM
Compound 4: a limit, no number (the forecaster's own chance of this, stated with the estimate: 40%); middle value at least 1.3-fold (0.12 log units) from the limit.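

With hydroxy at this position, in this assay compound 4 gives > 20000 nM, a limit of the assay, so a group with a hydrogen-bond donor and acceptor now sits at the same limit as chloro and bromo. Among the compounds shown here, the one readable step is an at least 1.7-fold higher number from compound 1 to compound 4 (0.23 log units; that floor lies within the scatter), only a floor, while the steps among compound 2, compound 3 and compound 4 cannot be read. The read-out offers no room to rank these groups: the limit of > 20000 nM in this assay, at which 3 of the 4 values shown sit.

The compounds shown leave open whether compound 2, compound 3 and compound 4 differ at all. Also open, from the compounds shown here alone, is what an amine or a carboxylic acid at this position would give.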